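A few compounds are considered here, and "the series" means these few. Any claim that something is new, unique, unknown or untested is made for them only; others in the source may bear on it.

Four compounds share one core and differ only in the group carried by the terminal amine nitrogen. Compound 1 `c1cncc(CNCCCCN(C[C@H]2Cc3ccccc3CN2)[C@H]2CCCc3cccnc32)c1` carries a (pyridin-3-yl)methyl group there, and in a functional assay on cells for antagonist activity at C-X-C chemokine receptor type 4 (Homo sapiens), read by fluorescence and calcium flux, with stated times of 25 min and 90 s (a lower number here means a stronger inhibitor, a higher number a weaker inhibitor), compound 1 gives 15.3 nM. Compound 2 `c1ccc(CNCCCCN(C[C@H]2Cc3ccccc3CN2)[C@H]2CCCc3cccnc32)cc1` carries a benzyl group instead, and in this assay compound 2 gives 20.1 nM; the step from one to the other is a 1.3-fold higher number from compound 1 to compound 2 (0.12 log units; within the scatter). Compound 3 `c1ccc2c(c1)CN[C@@H](CN(CCCCNC1CCCCC1)[C@H]1CCCc3cccnc31)C2` carries a cyclohexyl group, and in this assay compound 3 gives 75.2 nM, the highest of the three numbers: the step to it from the pyridine analogue is a 4.9-fold higher number from compound 1 to compound 3 (0.69 log units; beyond the scatter), and from the benzyl analogue a 3.7-fold higher number from compound 2 to compound 3 (0.57 log units; beyond the scatter).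

Compound 4 `c1ccc2c(c1)CN[C@@H](CN(CCCCNC1CCNCC1)[C@H]1CCCc3cccnc31)C2` is the next step from compound 3: piperidin-4-yl in place of cyclohexyl on an amine nitrogen. Both measured steps into compound 3 swapped an aromatic ring on a chain carbon for a saturated ring on the nitrogen itself, and both raised the number modestly. Among the compounds with values here, neither tests what happens when one ring carbon of that saturated ring becomes a nitrogen, so there is no directly comparable step. The expectation is therefore a modest move, most likely a lower number, as the step of a 1.9-fold lower number from compound 3 to compound 4 (0.27 log units; within the scatter) expresses. For compound 4 the estimate in this assay is 40 nM, with a range from 10 nM to 150 nM.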

Compound 4, half-maximal inhibitory concentration: 63.4 nM
Compound 4: the middle estimate sits 1.6-fold (0.20 log units) below what was measured; low and high end bracket the measured number.
By their numbers in this assay, from the lowest: compounds 1 and 2 (each within the scatter of the next); then compounds 4 and 3 (each within the scatter of the next).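

In this assay the swap of piperidin-4-yl for cyclohexyl adds one hydrogen-bond donor and one hydrogen-bond acceptor to the group on the amine nitrogen, yet the step is a 1.2-fold lower number from compound 3 to compound 4 (0.07 log units; within the scatter) and so shows no readable difference. The gap to the analogues with an aromatic ring also holds for this new saturated ring, with a 3.2-fold higher number from compound 2 to compound 4 (0.50 log units; beyond the scatter) and a 4.1-fold higher number from compound 1 to compound 4 (0.62 log units; beyond the scatter) as two modest steps, so compound 4 stands with compound 3 on the weaker side of compounds 1 and 2. No measurement shown offers a reason for either result.

Compounds 1 and 2 differ from compound 3 and compound 4 in two features at once, an aromatic ring and a chain carbon that carries it, so a cyclohexylmethyl or (piperidin-4-yl)methyl group would be needed to tell these two features apart. Also open, as far as these compounds go, is whether a tetrahydropyran-4-yl ring, with oxygen in place of the ring nitrogen, or a methyl group on the piperidine nitrogen would give a step beyond the scatter.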